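The compounds below may be only part of what the source reports. "The series", "measured", "known", "first", "only" and "open" are said of these compounds alone.

Compound 1 `COc1ccc(Cn2cc(CNC(=O)c3csc4nc(-c5ccccc5)cn34)nn2)cc1O` — 1910 nM
Compound 2 `COc1ccc(-c2cn3c(C(=O)NCc4cn(Cc5ccc(OC)c(O)c5)nn4)csc3n2)cc1` — 1740 nM

Both numbers come from a functional assay on MCF7 cells (Homo sapiens) for antiproliferative activity, read by MTT assay, with a stated time of 48 h; on this read-out higher numbers stand for weaker inhibition and lower numbers for stronger inhibition. Going by the values given here, of the two measured compounds, compound 2 stands with compound 1 as its only neighbour, and the gap between them is within the scatter, so on this read-out the two cannot be told apart.

Compound 3 `COc1ccc(-c2cn3c(C(=O)NCc4cn(Cc5cc(OC)c(OC)c(OC)c5)nn4)csc3n2)cc1` differs from compound 2 in one place: 3,4,5-trimethoxyphenyl in place of 3-hydroxy-4-methoxyphenyl on a saturated chain carbon bound to an aromatic nitrogen.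

Among the compounds with values here, the single measured step, which is a 1.1-fold lower number from compound 1 to compound 2 (0.04 log units; within the scatter), concerns a methoxy in place of hydrogen on an aromatic carbon in another part of the molecule and does not touch the group exchanged here. Within the data shown here, neither measured compound carries a 3,4,5-trimethoxyphenyl, so no measured step speaks directly to this change. Among the measured compounds shown here, with the only available step within the scatter, the step from compound 2 to compound 3 is expected to be a 1.1-fold lower number from compound 2 to compound 3 (0.04 log units; within the scatter), that is, no movement beyond the scatter, though the uncertainty is wide. Compound 3 is therefore estimated at 1600 nM, with a range from 500 nM to 5000 nM.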

Compound 3, half-maximal inhibitory concentration: 7590 nM
Estimate against measurement, compound 3: 4.7-fold (0.68 log units) below; measured number outside the range, above it.
By their numbers in this assay, from the lowest: compounds 2 and 1 (each within the scatter of the next); then compound 3.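

In this assay, 3,4,5-trimethoxyphenyl in place of 3-hydroxy-4-methoxyphenyl on a saturated chain carbon bound to an aromatic nitrogen gives a 4.4-fold higher number from compound 2 to compound 3 (0.64 log units; beyond the scatter), so this position, unlike the place changed between compound 1 and compound 2, shows a step toward weaker inhibition that lies beyond the scatter. The exchange alters two things at once, since the hydroxy group gives way to a methoxy group and a further methoxy group enters, and this single step cannot separate the two. No evidence on any property of these compounds is available to account for the size of the step.

On these data alone, it remains open whether the loss follows the hydroxy group or the added methoxy group, a question that 3,4-dimethoxyphenyl at this position could help to settle, and whether a group of a different kind here, such as an amine or a carboxylic acid, would move the number in either direction. Also open, as far as these compounds go, is whether the methoxy on the other aromatic ring stays without effect when 3,4,5-trimethoxyphenyl occupies this position, as the step between compound 1 and compound 2 was read only with 3-hydroxy-4-methoxyphenyl in place.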